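Notes on amine side-chain variation in a transporter series

The source may hold more compounds than are shown below. What is called first, only, known or untested is meant among the compounds shown, and "the series" means these compounds.

Measured so far:
compound 1 `CCCCCCCCCCc1ccc(-c2noc(CCCNC)n2)cc1`: 45%
compound 2 `CCCCCCCCCCc1ccc(-c2noc(-c3cccc(CN)c3)n2)cc1`: 2%

In an assay on HeLa cells for inhibition of sphingosine-1-phosphate transporter SPNS2 (Mus musculus), read by LC-MS, tested at 2 uM (a higher number here means more inhibition at the concentration tested (going by the name of the read-out), a lower number less inhibition), compound 1 gives 45%. Compound 2 gives 2%, the lowest of the two numbers available; its nearest neighbour is compound 1, and the step of a number 43 percentage points lower from compound 1 to compound 2 (beyond the scatter) lies beyond the scatter. Compound 3 `CCCCCCCCCCc1ccc(-c2noc(CCCN3CCCC3)n2)cc1` has not yet been measured. Its change relative to compound 2 is 3-(pyrrolidin-1-yl)propyl in place of 3-(aminomethyl)phenyl on an aromatic carbon. Within the data shown here, the only measured step bearing on this is a number 43 percentage points lower from compound 1 to compound 2 (beyond the scatter), in which 3-(aminomethyl)phenyl replaced 3-(methylamino)propyl on the same aromatic carbon; compound 3 undoes the aryl part of that change and again carries a propyl group ending in an amine, here pyrrolidin-1-yl rather than methylamino. A step of about a number 33 percentage points higher from compound 2 to compound 3 (beyond the scatter) is therefore expected, upward, broadly reversing the earlier loss. For compound 3 the estimate is 35%, with a range from 10% to 65%.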

Compound 3, a percentage reported as inhibition, at one concentration (the size of the read-out at that concentration, not a potency): 3%
Estimate against measurement, compound 3: 32 percentage points above, outside the stated range (below it).
By their numbers in this assay, from the lowest: compounds 2 and 3 (each within the scatter of the next); then compound 1.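

In this assay, a propyl chain ending in an amine is not enough on its own to keep the read-out: with the rest of the molecule unchanged, pyrrolidin-1-yl in place of methylamino gives a number 42 percentage points lower from compound 1 to compound 3 (beyond the scatter) and so the end of the chain counts at this position, not only its length. The step of a number 1 percentage points higher from compound 2 to compound 3 (within the scatter) puts 3-(pyrrolidin-1-yl)propyl and 3-(aminomethyl)phenyl level on this aromatic carbon, so the low number of compound 2 can no longer be tied to the phenyl ring alone. Nothing available explains why either change has the effect it does.

The compounds shown leave open whether a primary amine or a dimethylamino group at the end of the propyl chain would stand with compound 1 or with compound 3. As far as these compounds go, whether a smaller ring such as azetidine, or a longer chain carrying the methylamino group, would hold the read-out also remains open.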